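Replacing a Sulfur-Linked Benzyl with a Direct Cyclohexyl

The compounds below may be only part of what the source reports. "The series", "measured", "known", "first", "only" and "open" are said of these compounds alone.

Two compounds share one core. Compound 1 `CC(C(=O)NCc1ccc(C(C)(C)C)nc1SC1CCCC1)c1ccc(NS(C)(=O)=O)c(F)c1` gives 2.5 nM in an assay on cells for antagonist activity at transient receptor potential cation channel subfamily V member 1 (Homo sapiens), read by FLIPR and calcium flux, with a stated time of 6 min; on this read-out higher numbers stand for weaker inhibition and lower numbers for stronger inhibition. Compound 2 `CC(C(=O)NCc1ccc(C(C)(C)C)nc1SCc1ccccc1)c1ccc(NS(C)(=O)=O)c(F)c1` gives 4 nM, and the two numbers lie within the scatter of each other, as a 1.6-fold higher number from compound 1 to compound 2 (0.20 log units; within the scatter) shows. Compound 3 `CC(C(=O)NCc1ccc(C(C)(C)C)nc1C1CCCCC1)c1ccc(NS(C)(=O)=O)c(F)c1` carries cyclohexyl in place of benzylsulfanyl on an aromatic carbon. For the measured compounds named here, only that one measured step bears on this change, and it shows that exchanging an aromatic ring for a non-aromatic ring on a sulfur left the number essentially unchanged; removing the sulfur itself has no measured precedent here. A step of a 1.5-fold higher number from compound 2 to compound 3 (0.18 log units; within the scatter) is therefore expected, small and if anything toward a higher number. Compound 3 is estimated at 6 nM, within a range from 2 nM to 25 nM.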

Compound 3, inhibition constant: 3.1 nM
For compound 3 the middle estimate is 1.9-fold (0.29 log units) above the measured one; low and high end bracket the measured number.
By their numbers in this assay, from the lowest: compounds 1, 3 and 2 (each within the scatter of the next).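

In this assay, the sulfur link proves dispensable at this position, next to the ring nitrogen: with a 1.3-fold lower number from compound 2 to compound 3 (0.11 log units; within the scatter) and a 1.2-fold higher number from compound 1 to compound 3 (0.09 log units; within the scatter), both steps stay within the scatter. A cyclohexyl joined directly to the aromatic carbon therefore keeps the number in the same range as either sulfur-linked group. Nothing available explains why the number holds when the sulfur is gone.

From the compounds shown here alone, whether this position needs a ring at all remains open. A butyl chain, an amine or a carboxylic acid in the same place would address that question.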